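The source may report more compounds than this note shows. Statements on the series, on what has been measured and on what is new or still open speak of the compounds shown alone.

Working notes on the series in a functional assay on PANC-1 cells (Homo sapiens) for inhibition, read by MTT assay, with a stated time of 24 h, tested at 10 uM; on this read-out higher numbers stand for more inhibition at the one concentration tested (going by the name of the read-out) and lower numbers for less inhibition. The shared core is set by compound 1 `CCOc1cc(=O)n(CCCO)c2c1CC(C/C=C(\C)CCC=C(C)C)C(C)(C)C2`, which in this assay gives 67.8%. Compound 2 `CC(C)=CCC/C(C)=C/CC1Cc2c(OC(=O)Nc3ccccc3F)cc(=O)n(CCCO)c2CC1(C)C` carries a (2-fluorophenyl)carbamoyl in place of the ethyl on the ring oxygen and in this assay gives 71.6%, a step of a number 3.8 percentage points higher from compound 1 to compound 2 (within the scatter). Compound 3 `CC(C)=CCC/C(C)=C/CC1Cc2c(OC(=O)Nc3ccc(F)cc3F)cc(=O)n(CCCO)c2CC1(C)C` carries the (2,4-difluorophenyl)carbamoyl and in this assay gives 33.7%, which is the lowest of the three numbers; against compound 1 the step is a number 34.1 percentage points lower from compound 1 to compound 3 (beyond the scatter), and the single added fluoro on an aromatic carbon gives a number 37.9 percentage points lower from compound 2 to compound 3 (beyond the scatter).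

Compound 4 `CC(C)=CCC/C(C)=C/CC1Cc2c(OC(=O)Nc3ccc(Cl)c(Cl)c3)cc(=O)n(CCCO)c2CC1(C)C` is the next carbamate: 3,4-dichlorophenyl in place of 2,4-difluorophenyl on an amide-type nitrogen. Going by the values given here, no measured step changes fluorine for chlorine or moves the halogens to the 3,4-positions, so only the carbamate steps bear on it. Those steps show the carbamate ring substitution swinging the read-out widely in both directions, from within the scatter to a large fall. With the 2-position of the phenyl freed of fluorine, as in compound 2, a recovery is expected, though of uncertain size; the estimated step is a number 18.3 percentage points higher from compound 3 to compound 4 (beyond the scatter). For compound 4 the expected value in this assay is 52%, with a range of 25% to 78%.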

Compound 4, a percentage reported as inhibition, at one concentration (the size of the read-out at that concentration, not a potency): 20%
Beside the measured number, compound 4's estimate is 32 percentage points above it; the measured number lies below the stated range.
By their numbers in this assay, from the lowest: compound 4; then compound 3; then compounds 1 and 2 (each within the scatter of the next).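

In this assay, removing the 2,4-difluorophenyl in favour of 3,4-dichlorophenyl on the amide-type nitrogen brings no recovery, with a number 13.7 percentage points lower from compound 3 to compound 4 (beyond the scatter), and the gap to the 2-fluorophenyl carbamate is wider still, with a number 51.6 percentage points lower from compound 2 to compound 4 (beyond the scatter). Against the ethyl on the ring oxygen, the (3,4-dichlorophenyl)carbamoyl gives a number 47.8 percentage points lower from compound 1 to compound 4 (beyond the scatter), so a carbamate in this place does not by itself hold the read-out, and among the three carbamates shown, the two with dihalogenated phenyl groups, compound 3 and compound 4, both read low while compound 2, with its single fluoro, does not. No available evidence accounts for these differences.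

The compounds shown do not separate the number of halogens on the phenyl from their kind or their placement, as compound 3 and compound 4 differ in both kind and placement. From the compounds shown here alone, how a plain phenyl, a methoxyphenyl or a pyridyl on the same nitrogen would read stays open, as does whether these single-concentration percentages would keep their order across a range of concentrations.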